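Fluoro on the azole ring of the acetate ester

The compounds below may be only part of what the source reports. "The series", "measured", "known", "first", "only" and "open" are said of these compounds alone.

Measured so far in a functional assay on MV4-11 cells (Homo sapiens) for antiproliferative activity, read by luminescence, with a stated time of 72 h; on this read-out lower numbers stand for stronger inhibition and higher numbers for weaker inhibition:
compound 1 `O=C1CN(Cc2ccc(O)c3ncccc23)Cc2ncccc2N1`: 9600 nM
compound 2 `CC(C)(CCl)C(=O)Oc1ccc(Cn2ccnc2)c2cccnc12`: 8900 nM
compound 3 `CC(=O)Oc1ccc(Cn2ccnc2)c2cccnc12`: 28500 nM

Compound 3 stands highest of the three numbers in this assay, so it is the weakest of the measured set, with compound 1 and compound 2 both beyond the scatter below it. Within the data shown here, the only step measured on compound 3 is a 3.2-fold higher number from compound 2 to compound 3 (0.51 log units; beyond the scatter), which concerns the ester group on the carbonyl carbon; it is modest but beyond the scatter.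

Compound 4 `CC(=O)Oc1ccc(Cn2cnc(F)c2)c2cccnc12` differs from compound 3 by fluoro in place of hydrogen on an aromatic carbon. Among the measured compounds shown here, the change sits on the five-membered aromatic ring with 2 nitrogen, a part of the shared core that no measured pair varies. For the measured compounds named here, the step of a 3.2-fold higher number from compound 2 to compound 3 (0.51 log units; beyond the scatter) therefore does not bear on it, and there is no measured step that does; the series holds no information on substitution of that ring.

With nothing to anchor a direction, the working expectation for compound 4 is a step of no size beyond the scatter, a 1.0-fold lower number from compound 3 to compound 4 (0.01 log units; within the scatter), the fluoro in place of hydrogen being a single heavy atom with no donors or acceptors. Compound 4 is accordingly estimated at 28000 nM in this assay, within a range of 11000 nM to 70000 nM, the range kept wide since the change is unprecedented in the set.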

Compound 4, half-maximal inhibitory concentration: 2900 nM
Beside the measured number, compound 4's estimate is 9.7-fold (0.98 log units) above it; measured number outside the range, below it.
By their numbers in this assay, from the lowest: compound 4; then compounds 2 and 1 (each within the scatter of the next); then compound 3.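

Among these compounds, the ring substitution gives a result in this assay that no earlier pair could show: there is a 9.8-fold lower number from compound 3 to compound 4 (0.99 log units; beyond the scatter) on placing fluoro on an aromatic carbon of the five-membered aromatic ring with 2 nitrogen, next to the ring nitrogen. This part of the shared core is therefore not neutral to substitution, and on this read-out the lower number stands for stronger inhibition. Among the compounds shown here, the one earlier step, a 3.2-fold higher number from compound 2 to compound 3 (0.51 log units; beyond the scatter) on the carbonyl carbon, concerned the ester group, so the series now has two places where a single change moves the number beyond the scatter, and no measured evidence accounts for the effect of fluoro on this ring.

Chloro, methyl or a nitrile on the same aromatic carbon would show whether the gain is specific to fluoro or extends to other groups at this position. Also open, on these data alone, is whether fluoro gives a step of similar size when the acetate is replaced by the 1-(chloromethyl)-1-methylethyl ester group of compound 2, since only the acetate carries it here.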